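Working notes on cytotoxicity across four analogues

This account rests on a few compounds, and the source may have more. Where it says the series, first, only, none or still open, it means among the compounds named here.

Compound 1 `Cc1cn([C@@H]2O[C@H](CO)[C@@]3(OS(=O)(=O)C=C3NC(=O)NC(=O)c3ccccc3)[C@H]2O[Si](C)(C)C(C)(C)C)c(=O)n(C)c1=O`: 16000 nM
Compound 2 `Cc1cn([C@@H]2O[C@H](CO)[C@@]3(OS(=O)(=O)C=C3NC(=O)NC(=O)c3ccccc3)[C@H]2O)c(=O)n(C)c1=O`: > 50000 nM, a limit of the assay
Compound 3 `Cc1cn([C@@H]2O[C@H](CO[Si](C)(C)C(C)(C)C)[C@@]3(OS(=O)(=O)C=C3NC(=O)NC(=O)c3ccccc3)[C@H]2O[Si](C)(C)C(C)(C)C(C)C)c(=O)n(C)c1=O`: >= 100000 nM, a limit of the assay
Compound 4 `Cc1cn([C@@H]2O[C@H](COC(=O)c3ccccc3)[C@@]3(OS(=O)(=O)C=C3NC(=O)NC(=O)c3ccccc3)[C@H]2O[Si](C)(C)C(C)(C)C)c(=O)n(C)c1=O`: not yet measured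

Among the measured compounds shown here, in an ADME assay on HEL cells (Homo sapiens) for cytotoxicity, with a stated time of 3 days (on this read-out higher numbers stand for lower toxicity in this test and lower numbers for higher toxicity in this test), compound 1 gives 16000 nM, the only outright number among the three measured compounds. The result for compound 2 is a limit of the assay, (the limit of > 50000 nM in this assay, at which 1 of the 3 values shown sits). The result for compound 3 is likewise a limit, (the limit of >= 100000 nM in this assay, at which 1 of the 3 values shown sits). For the measured compounds named here, the single step measured between compounds that differ in one place is an at least 3.1-fold higher number from compound 1 to compound 2 (0.49 log units; beyond the scatter).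

Compound 4 differs from compound 1 by benzoyl in place of hydrogen on an oxygen on a saturated carbon. Going by the values given here, no measured step concerns an addition at this oxygen on its own. Compound 3, which carries additions both at this oxygen and elsewhere, sits at a limit, while compound 1 gives a number, so the pair offers only a hint that building out from compound 1 tends toward higher numbers in this assay. The step from compound 1 to compound 4 is therefore expected to be an increase of modest size, a 2.2-fold higher number from compound 1 to compound 4 (0.34 log units; beyond the scatter), with a real chance that only a limit is returned. Compound 4 is estimated at 35000 nM, between 9000 nM and 120000 nM.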

Compound 4, half-maximal cytotoxic concentration: 100000 nM
The estimate for compound 4 lay 2.9-fold (0.46 log units) below the measured number; low and high end bracket the measured number.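

In this assay, benzoyl in place of hydrogen on this oxygen on a saturated carbon, with the rest of compound 1 unchanged, gives a 6.3-fold higher number from compound 1 to compound 4 (0.80 log units; beyond the scatter), so a change at this position alone moves the read-out beyond the scatter. Among the compounds shown here, the only earlier compound with an addition at this oxygen also differs elsewhere, so this is the first reading of the position on its own. The rise on adding benzoyl here sits alongside an at least 3.1-fold higher number from compound 1 to compound 2 (0.49 log units; beyond the scatter), where a silicon-bearing group gives way to hydrogen at another oxygen, so across these two steps the number goes up with both an addition and a removal and does not track added size in one direction; nothing at hand gives a reason for the step at this position.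

Going by these compounds, whether the rise belongs to the aromatic ring or to the ester carbonyl stays open, and an acetyl or a benzyl group on this oxygen would separate the two. Also open, on these data alone, is whether benzoyl has the same effect without the silicon-bearing group on the other oxygen, since it is seen here only with that group in place.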